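A One-Carbon Extension on the Ring Nitrogen

This account rests on a few compounds, and the source may have more. Where it says the series, first, only, none or still open, it means among the compounds named here.

Compound 1 `CC(C)CN1CCCC[C@H]1C(=O)Nc1cc(C(C)(C)C)on1`: 0.1 h
Compound 2 `CC(C)(C)c1cc(NC(=O)[C@@H]2CCCCN2C2CCOCC2)no1`: 0.317 h

In an ADME assay (liver) for metabolic stability, with Liver microsome (Homo sapiens) as the target, read by LC-MS, using microsomes and NADPH, tested at 1 uM (a lower number here means that the compound disappears faster, a higher number that the compound lasts longer), compound 2 stands highest of the two measured values. Going by the values given here, the one measured step, a 3.2-fold higher number from compound 1 to compound 2 (0.50 log units; beyond the scatter), was modest. Compound 3 `CC(C)(C)c1cc(NC(=O)[C@@H]2CCCCN2CC2CCOCC2)no1` differs from compound 2 by (oxan-4-yl)methyl in place of oxan-4-yl on an amine nitrogen in a ring. Among the compounds with values here, no measured step covers a change of this kind, since the known step exchanges one whole group for another rather than lengthening one by a single carbon. The expected step is therefore small, a 1.3-fold lower number from compound 2 to compound 3 (0.10 log units; within the scatter), and may well lie within the scatter. Compound 3 is estimated at 0.25 h, with a range from 0.1 h to 0.6 h.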

Compound 3, half-life: 0.183 h
Beside the measured number, compound 3's estimate is 1.4-fold (0.14 log units) above it, within the range that was stated.
By their numbers in this assay, from the lowest: compounds 1, 3 and 2 (each within the scatter of the next, the first and the last beyond it).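

In this assay, lengthening oxan-4-yl to (oxan-4-yl)methyl on the amine nitrogen in a ring gives a 1.7-fold lower number from compound 2 to compound 3 (0.24 log units; within the scatter), so the extra carbon makes no clear difference here. Exchanging isopropyl for oxan-4-yl on the saturated chain carbon gives a 1.8-fold higher number from compound 1 to compound 3 (0.26 log units; within the scatter), which also cannot be told apart from scatter. Nothing available here explains these numbers. Still open, on these data alone, is whether a longer chain at this nitrogen, or an amine in place of the ring oxygen, would move the half-life clearly beyond the scatter.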